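The compounds below may be only part of what the source reports. "The series", "measured", "known", "first", "only" and "open" are said of these compounds alone.

Working notes on the series.

Compound 1 `O[C@H](COCCOC[C@@H](O)Cc1cn(Cc2ccc3ccccc3c2)nn1)Cc1ccc(-c2ccccc2)cc1` is the reference point. In a functional assay on HCT-116 cells (Homo sapiens) for inhibition, read by MTT assay, with a stated time of 72 h (on this read-out higher numbers stand for weaker inhibition of growth and lower numbers for stronger inhibition of growth), compound 1 gives 8600 nM, which is the higher of the two numbers recorded so far. Compound 3 `COC1=C(OC)C(=O)C(CCCCCCCCCCCCCCCn2cc(C[C@H](O)COCCOC[C@@H](O)Cc3ccc(-c4ccccc4)cc3)nn2)=C(C)C1=O`, which carries the long quinone-bearing chain on the same ring nitrogen, gives 1500 nM. Compound 2 `O[C@H](COCCOC[C@@H](O)Cc1c[nH]nn1)Cc1ccc(-c2ccccc2)cc1` gives only a limit in this assay, > 100000 nM. Among the compounds with values here, the one single-site step measured is an at least 11-fold higher number from compound 1 to compound 2 (1.06 log units; beyond the scatter); its size is bounded because the limit of > 100000 nM in this assay, at which 1 of the 3 values shown sits, marks the point past which nothing is read.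

Compound 4 `O[C@H](COCCOC[C@@H](O)Cc1cn(-c2ccc3[nH]ccc3c2)nn1)Cc1ccc(-c2ccccc2)cc1` differs from compound 1 in a single place: 1H-indol-5-yl in place of (naphthalen-2-yl)methyl on an aromatic nitrogen. The measured step from compound 1 to compound 2 is the one that bears on this change, since both remove the (naphthalen-2-yl)methyl group from the aromatic nitrogen; there, however, the group was replaced by hydrogen, whereas here a bicyclic aromatic group remains. Compound 4 is therefore expected to sit between compound 1 and the limit seen for compound 2, with the estimated step of a 2.1-fold higher number from compound 1 to compound 4 (0.32 log units; beyond the scatter) pointing toward weaker inhibition of growth. For compound 4 the estimate in this assay is 18000 nM, with a range from 5000 nM to 70000 nM.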

Compound 4, concentration for 50% growth inhibition: 15500 nM
For compound 4 the middle estimate is 1.2-fold (0.06 log units) above the measured one, and the stated range covers the measured number.
By their numbers in this assay, from the lowest: compound 3; then compounds 1 and 4 (each within the scatter of the next). At a limit, above all of these: compound 2.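

In this assay, a 1.8-fold higher number from compound 1 to compound 4 (0.26 log units; within the scatter), so on this aromatic nitrogen the 1H-indol-5-yl group, with its hydrogen-bond donor and no methyl link, reads the same as (naphthalen-2-yl)methyl within the scatter. There is also an at least 6.4-fold lower number from compound 2 to compound 4 (0.80 log units; beyond the scatter), which shows that a second bicyclic aromatic group, and not only (naphthalen-2-yl)methyl, gives a readable number where hydrogen does not. Compound 2 gives only a limit, so this step is a bound and not a size: the limit of > 100000 nM in this assay, at which 1 of the 4 values shown sits.

From the compounds shown here alone, whether the hydrogen-bond donor and the missing methyl link each matter, or offset one another, remains open. Also open, going by these compounds, is how an amine, a carboxylic acid or a simple alkyl chain on this ring nitrogen would read in this assay.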